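The source may hold more compounds than are shown below. What is called first, only, known or untested is meant among the compounds shown, and "the series" means these compounds.

Measured so far:
- compound 1 `CCNC(=S)Nc1cccc(C(F)(F)F)c1`: > 100000 nM
- compound 2 `CC[C@H]1CC[C@H](c2ccc(NC(=S)Nc3cccc(C(F)(F)F)c3)cc2)CC1`: 9000 nM

In an ADME assay on MDBK cells (Bos taurus) for cytotoxicity, read by MTT assay, with a stated time of 96 h (a higher number here means that more compound is tolerated, a lower number that less compound is tolerated), compound 1 gives only a limit, > 100000 nM, not a number. Compound 1 stands at the limit of > 100000 nM in this assay, at which 1 of the 2 values shown sits. Compound 2, in this assay, gives 9000 nM. Compound 3 `FC(F)(F)c1cccc(NC(=S)Nc2ccccc2Br)c1` is not yet measured. It differs from compound 1 by 2-bromophenyl in place of ethyl on an amide-type nitrogen. For the measured compounds named here, no measured step follows this change; the bulkier aryl substituent of compound 2 sits at a lower value, so a move of that kind, toward less tolerated compound, is expected for compound 3, though its size is uncertain. For compound 3 the expected step is an at least 2.5-fold lower number from compound 1 to compound 3 (0.39 log units; beyond the scatter). Compound 3 is estimated at 40000 nM, within 10000 nM to 150000 nM.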

Compound 3, half-maximal cytotoxic concentration: > 100000 nM
Compound 3 ended at the assay's limit; the forecaster's own chance of this, stated with the estimate: 35%; middle value at least 2.5-fold (0.39 log units) from the limit.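

No step can be read from compound 1 to compound 3 in this assay: both give only a limit, not a number. As far as these compounds go, whether 2-bromophenyl in place of ethyl on an amide-type nitrogen changes the tolerated concentration at all, and in which direction, stays open.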